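Extending the imine substituent of compound 3

This account rests on a few compounds, and the source may have more. Where it says the series, first, only, none or still open, it means among the compounds named here.

Of the compounds shown here, three built on a shared core have been tested in an ADME assay on HeLa cells (Homo sapiens) for cytotoxicity, read by MTT assay, with a stated time of 72 h; a lower number here means that less compound is tolerated, a higher number that more compound is tolerated. Compound 1 `Nc1sc2c(c1-c1nc3cc(Cl)ccc3s1)CCC2` gives 75.1 ug/mL, and compound 2 `Nc1sc2c(c1-c1nc3cc(Cl)ccc3s1)CCCC2` gives 107 ug/mL. Compound 3 `Clc1ccc(/C=N/c2sc3c(c2-c2nc4ccccc4s2)CCC3)cc1` gives 380 ug/mL, the highest of the three numbers; its nearest neighbour is compound 2, its furthest is compound 1, and both gaps lie beyond the usual scatter. No pair among these three compounds differs in only one place, so no single step between measured compounds can be read off, and the tolerated concentration of compound 3 has to stand on its own.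

Compound 4 `C(=C/c1ccccc1)\C=N\c1sc2c(c1-c1nc3ccccc3s1)CCC2` has not yet been measured in this assay. It departs from compound 3 in one place: 2-phenylethenyl in place of 4-chlorophenyl on a carbon with a double bond to nitrogen. The aromatic ring is kept, the chlorine is given up, and a double bond outside aromatic rings is gained. Nothing in the measured set shows how such an exchange moves the read-out, so compound 4 is expected to stay near compound 3, and the expected step is a 1.3-fold lower number from compound 3 to compound 4 (0.10 log units; within the scatter), not beyond the scatter. For compound 4 the estimate in this assay is 300 ug/mL, with a range from 120 ug/mL to 700 ug/mL.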

Compound 4, half-maximal cytotoxic concentration: 100 ug/mL
Compound 4: middle estimate off by 3.0-fold (0.48 log units), on the high side; the whole stated range lies above it.
By their numbers in this assay, from the lowest: compounds 1, 4 and 2 (each within the scatter of the next); then compound 3.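

Among these compounds, on the carbon with a double bond to nitrogen, putting 2-phenylethenyl in place of 4-chlorophenyl gives a 3.8-fold lower number from compound 3 to compound 4 (0.58 log units; beyond the scatter) in this assay, the first step that can be read from a single change, and it shows that the read-out responds to what is carried at this place. Keeping a six-membered aromatic ring of carbon only in the group does not hold the number in place, since less of compound 4 is tolerated once the chlorine is lost and a double bond outside aromatic rings is gained. Nothing available explains this step, and the two changes within the exchange cannot be told apart.

The compounds shown leave open whether the chlorine or the double bond accounts for the step, a question that a plain phenyl, a saturated 2-phenylethyl group or a 2-(4-chlorophenyl)ethenyl group at the same place would address. They also leave open how other groups there, such as a 4-methoxyphenyl, a pyridyl ring or a longer chain ending in an amine, would move the tolerated concentration.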